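Methyl Ester Analogue in a Permeability Series

The compounds below may be only part of what the source reports. "The series", "measured", "known", "first", "only" and "open" are said of these compounds alone.

Of the compounds shown here, three have been measured in an ADME assay for permeability, using PAMPA, with a stated time of 4 h; on this read-out higher numbers stand for higher permeability and lower numbers for lower permeability. Compound 1 `CN1CCN(c2ccc(C(=O)Oc3ccccc3)cc2NC(=O)c2ccc(F)c([N+](=O)[O-])c2)CC1` gives 60 10^-6 cm/s. Compound 2 `COC(=O)c1ccc(N2CCN(C)CC2)c(NC(=O)c2ccc(F)c([N+](=O)[O-])c2)c1` differs from compound 1 by methyl in place of phenyl on an oxygen next to a carbonyl group; in this assay compound 2 gives 52.4 10^-6 cm/s, and the step is a 1.1-fold lower number from compound 1 to compound 2 (0.06 log units; within the scatter). Compound 3 `Cc1c(F)c([N+](=O)[O-])cc(C(=O)Nc2cc(C(=O)Oc3ccccc3)ccc2N2CCN(C)CC2)c1Cl` differs from compound 1 by 2-chloro-4-fluoro-3-methyl-5-nitrophenyl in place of 4-fluoro-3-nitrophenyl on a carbonyl carbon; in this assay compound 3 gives 56.3 10^-6 cm/s, a step of a 1.1-fold lower number from compound 1 to compound 3 (0.03 log units; within the scatter). All three numbers thus sit close together.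

Compound 4 `COC(=O)c1ccc(N2CCN(C)CC2)c(NC(=O)c2cc([N+](=O)[O-])c(F)c(C)c2Cl)c1` has not yet been measured. It differs from compound 3 by methyl in place of phenyl on an oxygen next to a carbonyl group, the same change that turns compound 1 into compound 2; it occurs twice among these compounds, and the place is identical in both cases, on an oxygen next to a carbonyl group whose other neighbours are the carbonyl carbon. That change gave a 1.1-fold lower number from compound 1 to compound 2 (0.06 log units; within the scatter). A step of similar size is expected here, a 1.1-fold lower number from compound 3 to compound 4 (0.03 log units; within the scatter), resting on that single earlier pair alone. Compound 4 is therefore estimated at 52 10^-6 cm/s, with a likely range from 35 10^-6 cm/s to 78 10^-6 cm/s.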

Compound 4, apparent permeability: 74.8 10^-6 cm/s
Beside the measured number, compound 4's estimate is 1.4-fold (0.16 log units) below it; the range from low to high includes it.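

In this assay, the change from phenoxycarbonyl to methoxycarbonyl on the core of compound 3 gives a 1.3-fold higher number from compound 3 to compound 4 (0.12 log units; within the scatter), and setting this beside the earlier case shows no real difference between the two cores: the same change on two cores in this assay, a 1.1-fold lower number (0.06 log units; within the scatter) from compound 1 to compound 2 and a 1.3-fold higher number (0.12 log units; within the scatter) from compound 3 to compound 4, 1.5-fold (0.18 log units) apart, within the scatter of two such steps. On these two cores, then, the change carries over in the sense that neither step stands out from the usual scatter of repeated measurements, so swapping phenyl for methyl at this place leaves the read-out about where it was. This does not show that the change is without any effect in general, since two small steps cannot reveal a slight real shift hidden in the scatter, and two pairs say nothing about cores beyond these.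

Going by these compounds, how a longer chain such as ethyl or butyl on that oxygen would read stays open, as does a carboxylic acid or a primary amide in place of the whole methoxycarbonyl group. Whether the two cores would also behave alike on any other read-out is likewise left open.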